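A few compounds are considered here, and "the series" means these few. Any claim that something is new, unique, unknown or untested is made for them only; others in the source may bear on it.

Series notes. Among the compounds with values here, compound 3 `C#CCC[C@H]1O[C@@H](C)[C@H](C)C(Cl)=C1[Si](C)(C)C` gives 37000 nM in a functional assay on SW1573 cells (Homo sapiens) for antiproliferative activity (on this read-out higher numbers stand for weaker inhibition of growth and lower numbers for stronger inhibition of growth), the lowest of the three numbers so far, though its gaps to compound 1 and compound 2 both sit within the scatter. Compound 1 `C[C@@H]1O[C@H](C2CCCCC2)C([Si](C)(C)C)=C(Cl)[C@H]1C` gives 41000 nM and compound 2 `C[C@@H]1O[C@H](CCC=C(Br)Br)C([Si](C)(C)C)=C(Cl)[C@H]1C` gives 43000 nM in this assay. The steps of a 1.0-fold higher number from compound 1 to compound 2 (0.02 log units; within the scatter) and a 1.1-fold lower number from compound 1 to compound 3 (0.04 log units; within the scatter) show that changing the group on the saturated ring carbon leaves the number essentially untouched, and the step of a 1.2-fold lower number from compound 2 to compound 3 (0.07 log units; within the scatter) shows the same for a change at the end of that chain.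

Compound 4 `C=CCC[C@H]1O[C@@H](C)[C@H](C)C(Cl)=C1[Si](C)(C)C` differs from compound 3 by vinyl in place of ethynyl on a saturated chain carbon, two bonds along the chain from a saturated ring carbon. This is the closest analogue of the step from compound 2 to compound 3, which was within the scatter, and nothing else in the set moves the number either. The expected step of a 1.1-fold higher number from compound 3 to compound 4 (0.02 log units; within the scatter) is therefore none beyond the scatter. Compound 4 is expected to give about 39000 nM in this assay, with a range from 20000 nM to 78000 nM.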

Compound 4, concentration for total growth inhibition: 55000 nM
Beside the measured number, compound 4's estimate is 1.4-fold (0.15 log units) below it, and the stated range covers the measured number.
By their numbers in this assay, from the lowest: compounds 3, 1, 2 and 4 (each within the scatter of the next).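

Ethynyl and vinyl on the saturated chain carbon, two bonds along the chain from a saturated ring carbon, cannot be told apart in this assay (a 1.5-fold higher number from compound 3 to compound 4 (0.17 log units; within the scatter)), so swapping the triple bond for a double bond has no readable effect here. The same holds when vinyl replaces 2,2-dibromoethenyl (a 1.3-fold higher number from compound 2 to compound 4 (0.11 log units; within the scatter)) and when but-3-en-1-yl replaces cyclohexyl on the saturated ring carbon (a 1.3-fold higher number from compound 1 to compound 4 (0.13 log units; within the scatter)), which leaves compound 1, compound 2, compound 3 and compound 4 all within the scatter of one another. Nothing available bears on why the number stays flat at this place.

From the compounds shown here alone, whether an amine, a carboxylic acid or a much longer chain at this place would move the number remains open. Also open, going by these compounds, is what replacing the trimethylsilyl group or the chlorine on the shared core would do.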